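Fluoro in place of hydrogen: expected effect on growth inhibition

The compounds below may be only part of what the source reports. "The series", "measured", "known", "first", "only" and "open" are said of these compounds alone.

Among the compounds with values here, compound 1 `COc1ccc(-c2ccc(-c3ccc(C(=N)N)cc3)s2)cc1` holds the lower of the two numbers measured so far: in a functional assay on HCT-116 cells (Homo sapiens) for inhibition, read by sulforhodamine B assay, with a stated time of 48 h (a lower number here means a stronger inhibitor of growth, a higher number a weaker inhibitor of growth), compound 1 gives 186 nM. Compound 2 `N=C(N)c1ccc(-c2ccc(-c3cc(Cl)cc(Cl)c3)s2)cc1` gives 468 nM in this assay, a gap beyond the usual scatter. Within the data shown here, no two measured compounds differ in one place, so no step size is known from the data. Compound 3 `COc1ccc(-c2ccc(-c3ccc(C(=N)N)c(F)c3)s2)cc1` differs from compound 1 by fluoro in place of hydrogen on an aromatic carbon. Starting from compound 1 at 186 nM, the expected step is a 1.1-fold higher number from compound 1 to compound 3 (0.03 log units; within the scatter), no change beyond the scatter. Compound 3 is therefore estimated at 200 nM, within 90 nM to 450 nM.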

Compound 3, concentration for 50% growth inhibition: 3040 nM
Compound 3: the middle estimate sits 15-fold (1.18 log units) below what was measured; measured number outside the range, above it.
By their numbers in this assay, from the lowest: compound 1; then compound 2; then compound 3.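

In this assay, within the data shown here, fluoro in place of hydrogen gives a 16-fold higher number from compound 1 to compound 3 (1.21 log units; beyond the scatter), the first one-place step. This aromatic carbon, ortho to a group of 3 heavy atoms, is therefore sensitive, since a single added fluorine atom costs much of the growth inhibition of compound 1. Nothing available bears on what lies behind this loss. From the compounds shown here alone, whether methyl, hydroxy or an amine on this carbon would give a similar step remains open. So does whether fluoro on another carbon of the same ring would.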